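The source may report more compounds than this note shows. Statements on the series, on what has been measured and on what is new or still open speak of the compounds shown alone.

In a functional assay on DU-145 cells (Homo sapiens) for cytotoxicity, read by MTT assay, with a stated time of 48 h (on this read-out higher numbers stand for weaker inhibition and lower numbers for stronger inhibition), compound 1 `CCOC(=O)c1c(-c2c(Cl)c3ccccc3oc2=O)nn(-c2ccc(Br)cc2)c1C(=O)OCC` gives 32000 nM. In this assay compound 2 `CCOC(=O)c1c(-c2cc3ccccc3oc2=O)nn(-c2cccc(F)c2)c1C(=O)OCC` gives 32000 nM. In this assay compound 3 `CCOC(=O)c1c(-c2cc3ccccc3oc2=O)nn(-c2ccc(Cl)cc2)c1C(=O)OCC` gives 26000 nM.

Compound 3 stands with compound 1 and compound 2 inside the usual scatter of the assay: none of the three is set apart from the others. Compound 4 `CCOC(=O)c1c(-c2cc3ccccc3oc2=O)nn(-c2ccc(Br)cc2)c1C(=O)OCC` differs from compound 3 by bromo in place of chloro on an aromatic carbon. Within the data shown here, the one measured step that touches the same six-membered ring, a 1.2-fold lower number from compound 2 to compound 3 (0.09 log units; within the scatter), lay within the scatter. Among the measured compounds shown here, no measured step exchanges chloro for bromo anywhere. Compound 4 is therefore expected to show no step beyond the scatter, a 1.2-fold higher number from compound 3 to compound 4 (0.06 log units; within the scatter). Compound 4 is estimated at 30000 nM, with a range from 15000 nM to 60000 nM.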

Compound 4, half-maximal inhibitory concentration: 61000 nM
The estimate for compound 4 lay 2.0-fold (0.31 log units) below the measured number, and the stated range ends below it.
By their numbers in this assay, from the lowest: compounds 3, 1, 2 and 4 (each within the scatter of the next, the first and the last beyond it).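

In this assay, among these compounds, the change from 4-chlorophenyl to 4-bromophenyl gives the only step beyond the scatter, a 2.3-fold higher number from compound 3 to compound 4 (0.37 log units; beyond the scatter), so the halogen at this place does register, if modestly. The two other steps to this compound stay within the scatter: 4-bromophenyl in place of 3-fluorophenyl gives a 1.9-fold higher number from compound 2 to compound 4 (0.28 log units; within the scatter), and removing the chloro from the core gives a 1.9-fold higher number from compound 1 to compound 4 (0.28 log units; within the scatter). No measured evidence accounts for the difference between chloro and bromo here. The compounds shown leave open what iodo or a methoxy group would do at this place. They also leave open whether chloro and bromo differ in the same way on the core of compound 1.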